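Swapping phenyl for 3,4-dichlorophenyl on a triazole nitrogen

The source may hold more compounds than are shown below. What is called first, only, known or untested is meant among the compounds shown, and "the series" means these compounds.

Compound 1 `COc1cc(-c2ncnn2-c2ccccc2)cc(OC)c1OC` was tested in a functional assay on K562 cells (Homo sapiens) for antiproliferative activity, read by MTT assay, with a stated time of 72 h; a higher number here means a weaker inhibitor, a lower number a stronger inhibitor. In this assay compound 1 gives only a limit, > 10000 nM, not a number. Compound 2 `COc1cc(-n2ncnc2-c2ccc(F)cc2)cc(OC)c1OC` likewise gives only a limit in this assay, > 10000 nM. So compound 1 stands at the assay limit, and the one other value shown sits there too: the limit of > 10000 nM in this assay, at which 2 of the 2 values shown sit. Among the measured compounds shown here, no step between two measured compounds is available, so nothing shows how any change moves the read-out.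

Compound 3 `COc1cc(-c2ncnn2-c2ccc(Cl)c(Cl)c2)cc(OC)c1OC` differs from compound 1 by 3,4-dichlorophenyl in place of phenyl on an aromatic nitrogen. With both measured compounds sitting at the limit, the step from compound 1 to compound 3 is expected to be small, if any, and most likely within the scatter: an at least 1.1-fold lower number from compound 1 to compound 3 (0.04 log units; that floor lies within the scatter). Compound 3 is therefore expected to give about 9000 nM in this assay, somewhere between 2500 nM and 30000 nM, with a real chance that only a limit is reported again.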

Compound 3, half-maximal inhibitory concentration: > 10000 nM
Compound 3 gave a limit, no number; the forecaster's own chance of this, stated with the estimate: 60%; middle value at least 1.1-fold (0.04 log units) from the limit.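

Compound 1 and compound 3 both give only a limit in this assay, so swapping phenyl for 3,4-dichlorophenyl yields no readable step: the limit of > 10000 nM in this assay, at which 3 of the 3 values shown sit.

None of the compounds shown gives a number, which leaves open how any change on the shared core moves the read-out.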